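Replacing a benzyloxy with an amino group in a urea series

This account rests on a few compounds, and the source may have more. Where it says the series, first, only, none or still open, it means among the compounds named here.

The three measured compounds share a urea core bearing a diisopropylphenyl group on one side and a substituted cyclopentylmethyl group on the other. In an assay on microsomes for inhibition of acyl-CoA:cholesterol acyltransferase (Oryctolagus cuniculus) (on this read-out lower numbers stand for stronger inhibition and higher numbers for weaker inhibition), compound 1 `Cc1ccccc1C1(CNC(=O)Nc2c(C(C)C)cccc2C(C)C)CCCC1` gives 17 nM, compound 2 `CC(C)c1cccc(C(C)C)c1NC(=O)NCC1(c2ccc(CC(C)(C)C)cc2)CCCC1` gives 159 nM, and compound 3 `CC(C)c1cccc(C(C)C)c1NC(=O)NCC1(c2ccc(OCc3ccccc3)cc2)CCCC1` gives 34 nM. Among these numbers compound 3 stands second highest: it sits between compound 1, with the difference to it within the scatter, and compound 2, from which it is separated by a step beyond the scatter, a 4.7-fold lower number from compound 2 to compound 3 (0.67 log units; beyond the scatter). The other step, a 9.4-fold higher number from compound 1 to compound 2 (0.97 log units; beyond the scatter), involves a change of the whole aryl group.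

Compound 4 `CC(C)c1cccc(C(C)C)c1NC(=O)NCC1(c2ccc(N)cc2)CCCC1` differs from compound 3 in one place: amino in place of benzyloxy on an aromatic carbon. Within the data shown here, no measured step removes a group of this kind outright, so neither step bears on it directly; the closest comparison is the exchange at the same position, a 4.7-fold lower number from compound 2 to compound 3 (0.67 log units; beyond the scatter), which shows that changes here move the read-out by a modest but real amount. Removing most of the group is therefore expected to shift this assay by a modest to moderate amount toward a higher number, a 7.4-fold higher number from compound 3 to compound 4 (0.87 log units; beyond the scatter). Compound 4 is accordingly estimated at 250 nM, within a range from 50 nM to 1200 nM.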

Compound 4, half-maximal inhibitory concentration: 29 nM
Compound 4: the middle estimate sits 8.6-fold (0.94 log units) above what was measured; the measured number lies below the stated range.
By their numbers in this assay, from the lowest: compounds 1, 4 and 3 (each within the scatter of the next); then compound 2.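

In this assay, the step of a 1.2-fold lower number from compound 3 to compound 4 (0.07 log units; within the scatter) shows that at this place, para to a large group, benzyloxy can be exchanged for amino without a shift beyond the scatter, so the six-membered aromatic ring of the benzyloxy and most of its heavy atoms are not required to keep the read-out at this level in this pair. Group size alone therefore does not order this position: the much larger benzyloxy and the small amino read alike, yet neopentyl goes against any simple trend with size, as the step of a 5.5-fold lower number from compound 2 to compound 4 (0.74 log units; beyond the scatter) lies beyond the scatter, while the step of a 1.7-fold higher number from compound 1 to compound 4 (0.23 log units; within the scatter) places the 4-aminophenyl compound within the scatter of the 2-methylphenyl compound. Nothing among the data given accounts for why these groups read as they do.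

The compounds shown leave open whether a methoxy, a dimethylamino or an acetamido group at this same place would read like amino and benzyloxy or like neopentyl. They also leave open whether a carboxylic acid would be accepted here, and whether the parity between amino and benzyloxy would hold on any read-out other than this one.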